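From piperidin-1-yl to 2,6-dimethylpiperidin-1-yl in compound 2

A few compounds are considered here, and "the series" means these few. Any claim that something is new, unique, unknown or untested is made for them only; others in the source may bear on it.

Measured so far in a physicochemical assay for solubility, in phosphate buffer, measured as kinetic solubility, at pH 7.4; a lower number here means a less soluble compound, a higher number a more soluble compound 
- compound 1 `Cc1ccccc1-c1nc(CN2CCC(C(=O)NCCCN3CCC(C)(C)CC3)CC2)c(C)o1` reads > 69 ug/mL (a limit)
- compound 2 `Cc1ccccc1-c1nc(CN2CCC(C(=O)NCCCN3CCCCC3)CC2)c(C)o1` reads > 65 ug/mL (a limit)

In this assay compound 2 stands at > 65 ug/mL and this is a limit, not a number. Compound 3 `Cc1ccccc1-c1nc(CN2CCC(C(=O)NCCCN3[C@H](C)CCC[C@@H]3C)CC2)c(C)o1` differs from it in one place, on a saturated chain carbon, three bonds along the chain from an amide-type nitrogen: 2,6-dimethylpiperidin-1-yl in place of piperidin-1-yl on a saturated chain carbon, three bonds along the chain from an amide-type nitrogen. Within the data shown here, the only measured step at that place is a step that the two limits leave unreadable from compound 1 to compound 2 and it gives no size to carry over. It does show one thing. Compound 1, which bears 4,4-dimethylpiperidin-1-yl at that place, reads > 69 ug/mL and this too is a limit. So the one measured compound with added methyl groups on this ring gave no number, and the expectation for compound 3 rests on that alone. What is expected in this assay is a step that the limit leaves unreadable from compound 2 to compound 3, which means no step beyond the scatter in either direction, and quite possibly another reading that is only a limit. For compound 3 the estimated value is 69 ug/mL, with an expected range from 40 ug/mL to 80 ug/mL.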

Compound 3, solubility: > 69 ug/mL
Compound 3: no number, only a limit; the forecaster's own chance of this, stated with the estimate: 75%; the middle value sits exactly at the limit.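

In this assay, compound 3 gives only a limit, as do compound 1 and compound 2, so no step among these three compounds can be read. The compounds shown leave open how far each true value lies from its limit, and whether piperidin-1-yl, 4,4-dimethylpiperidin-1-yl and 2,6-dimethylpiperidin-1-yl differ at all at this place.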